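A few compounds are considered here, and "the series" means these few. Any claim that something is new, unique, unknown or untested is made for them only; others in the source may bear on it.

Working notes on the series.

Among the measured compounds shown here, compound 1 `Nc1ccccc1NC(=O)c1ccc(CNC(=O)c2n[nH]cc2NC(=O)c2ccccc2Cl)cc1` is measured in a functional assay on SMMC-7721 cells (Homo sapiens) for inhibition, read by CCK-8 assay, with a stated time of 72 h (on this read-out higher numbers stand for weaker inhibition and lower numbers for stronger inhibition), at 12900 nM, the second highest of the three numbers so far. Compound 3 `O=C(NO)c1ccc(CNC(=O)c2n[nH]cc2NC(=O)c2c(Cl)cccc2Cl)cc1` gives 14600 nM in this assay; compound 2 `Nc1ccccc1NC(=O)c1ccc(CNC(=O)c2n[nH]cc2NC(=O)c2ccccc2)cc1` gives 6620 nM. Compound 1 and compound 3 differ in two places, so their values are only set side by side: they lie within the scatter of one another. For the measured compounds named here, the one measured step that bears on the change at hand is a 1.9-fold lower number from compound 1 to compound 2 (0.29 log units; within the scatter), which runs the other way, with hydrogen in place of chloro on an aromatic carbon.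

Compound 4 `Nc1ccccc1NC(=O)c1ccc(CNC(=O)c2n[nH]cc2NC(=O)c2c(Cl)cccc2Cl)cc1` differs from compound 1 in one place: chloro in place of hydrogen on an aromatic carbon. The reverse step, a 1.9-fold lower number from compound 1 to compound 2 (0.29 log units; within the scatter), is within the scatter, and compound 3, which also carries a 2,6-dichlorophenyl, stands at 14600 nM next to compound 1. No step beyond the scatter is therefore expected in this assay; if anything, a slightly higher number is expected for compound 4, a 1.2-fold higher number from compound 1 to compound 4 (0.09 log units; within the scatter). Compound 4 is estimated at 16000 nM, with a range of 7000 nM to 36000 nM.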

Compound 4, half-maximal inhibitory concentration: 7760 nM
Compound 4: the middle estimate sits 2.1-fold (0.31 log units) above what was measured, and the stated range covers the measured number.
By their numbers in this assay, from the lowest: compounds 2, 4, 1 and 3 (each within the scatter of the next, the first and the last beyond it).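

In this assay, a second chloro on this aromatic ring adds no step beyond the scatter: a 1.7-fold lower number from compound 1 to compound 4 (0.22 log units; within the scatter), and a 1.2-fold higher number from compound 2 to compound 4 (0.07 log units; within the scatter). With the 2,6-dichlorophenyl held constant, the change on the amide-type nitrogen also stays within the scatter: a 1.9-fold lower number from compound 3 to compound 4 (0.27 log units; within the scatter), so neither place has yet given a readable effect on this read-out. No measured evidence on these compounds accounts for these numbers. Going by these compounds, whether a group other than chloro on this ring, such as methoxy, nitrile or an amine, gives a step beyond the scatter remains open. Also open, on these data alone, is whether a carboxylic acid or a longer chain on the carbonyl carbon, in place of the 2,6-dichlorophenyl, would do so.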